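Amide to urea exchange on compound 3

The source may hold more compounds than are shown below. What is called first, only, known or untested is meant among the compounds shown, and "the series" means these compounds.

Measured so far:
Compound 1, `CCCC(=O)NCCCc1cccc2oc(CCCCc3ccccc3)cc12`, gives 82 nM in an assay on NIH3T3 cells for binding affinity to melatonin receptor type 1B (Homo sapiens); a lower number here means a stronger inhibitor, a higher number a weaker inhibitor.
Compound 2, `CCNC(=O)NCCCc1cccc2oc(CCCCc3ccccc3)cc12`, gives 52 nM in this assay.
Compound 3, `CC(=O)N[C@H]1CCN(c2cccc3oc(CCCCc4ccccc4)cc23)C1`, gives 14 nM in this assay.

Compound 3 holds the lowest number of the three, set apart by a 5.9-fold lower number from compound 1 to compound 3 (0.77 log units; beyond the scatter) and by a 3.7-fold lower number from compound 2 to compound 3 (0.57 log units; beyond the scatter). Compound 4, `CCNC(=O)N[C@H]1CCN(c2cccc3oc(CCCCc4ccccc4)cc23)C1`, differs from compound 3 in one place: ethylamino in place of methyl on a carbonyl carbon. Going by the values given here, the only measured step of the same kind is a 1.6-fold lower number from compound 1 to compound 2 (0.20 log units; within the scatter), where ethylamino replaced propyl on a carbonyl carbon and the number barely moved. The same exchange on compound 3 is therefore expected to shift the number little, if at all, in this assay: a 1.4-fold lower number from compound 3 to compound 4 (0.15 log units; within the scatter). Compound 4 is thus estimated at 10 nM, in a range from 4 nM to 25 nM.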

Compound 4, inhibition constant: 98 nM
Beside the measured number, compound 4's estimate is 9.8-fold (0.99 log units) below it, outside the stated range (above it).
By their numbers in this assay, from the lowest: compound 3; then compounds 2, 1 and 4 (each within the scatter of the next).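

Going by these compounds alone, at this carbonyl carbon, ethylamino does not act the same way in every compound: in the acetamido compound the exchange to (ethylcarbamoyl)amino gives a 7.0-fold higher number from compound 3 to compound 4 (0.85 log units; beyond the scatter), whereas the one earlier step of this kind gave a 1.6-fold lower number from compound 1 to compound 2 (0.20 log units; within the scatter). The exchange that left the number within the scatter there thus costs binding here, so the earlier step does not carry over to this compound. The shown compounds cannot separate the entering nitrogen from the longer chain, since a methylamino or a plain propyl on this carbonyl carbon of compound 3 would be needed to tell them apart. Nothing at hand explains why the two steps differ.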